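Benzyloxy in place of 5-methoxypyrazin-2-yl

The source may hold more compounds than are shown below. What is called first, only, known or untested is meant among the compounds shown, and "the series" means these compounds.

Measured so far in an ADME assay on microsomes from liver (Homo sapiens) for metabolic stability; on this read-out lower numbers stand for a shorter-lived compound and higher numbers for a longer-lived compound:
- compound 1 `COc1cc(OCc2cccc(-c3ccc(C(F)(F)F)cn3)c2)c2cc(-c3cn4nc(OC)sc4n3)oc2c1` gives 0.733 h
- compound 2 `COc1cc(OCc2cccc(-c3ccc(OC)nc3)c2)c2cc(-c3cn4nc(OC)sc4n3)oc2c1` gives 0.733 h
- compound 3 `COc1cc(OCc2cccc(-c3cnc(OC)cn3)c2)c2cc(-c3cn4nc(OC)sc4n3)oc2c1` gives 1.48 h

Compound 3 stands highest of the three, with both steps to it beyond the scatter. On an aromatic carbon meta to a large group, compound 4 `COc1cc(OCc2cccc(OCc3ccccc3)c2)c2cc(-c3cn4nc(OC)sc4n3)oc2c1` has benzyloxy in place of 5-methoxypyrazin-2-yl on an aromatic carbon and so departs from the groups measured there. The step of a 2.0-fold higher number from compound 1 to compound 3 (0.31 log units; beyond the scatter) and the step of a 2.0-fold higher number from compound 2 to compound 3 (0.31 log units; beyond the scatter) are both modest, while the step of no change at the digits printed from compound 1 to compound 2 (within the scatter) shows nothing. None of them introduces benzyloxy, so they are only a loose guide. With compound 3 at 1.48 h as the top number, a modest step to a lower number in this assay is expected. The estimated step is a 1.9-fold lower number from compound 3 to compound 4 (0.27 log units; within the scatter) and it remains uncertain. For compound 4 the expected value is 0.8 h with a range of 0.35 h to 1.6 h in this estimate.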

Compound 4, half-life: 1.43 h
Compound 4: the middle estimate sits 1.8-fold (0.25 log units) below what was measured; the measured number falls inside the stated range.
By their numbers in this assay, from the lowest: compounds 1, 2, 4 and 3 (each within the scatter of the next, the first and the last beyond it).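

In this assay, the aromatic carbon meta to a large group accepts benzyloxy, a ring of carbon only, in place of the 5-methoxypyrazin-2-yl with a 1.0-fold lower number from compound 3 to compound 4 (0.01 log units; within the scatter). The other two steps, a 2.0-fold higher number from compound 2 to compound 4 (0.29 log units; within the scatter) and a 2.0-fold higher number from compound 1 to compound 4 (0.29 log units; within the scatter), also stay within the scatter, so compound 4 cannot be separated from any earlier compound, although compound 3 stood apart from compound 1 and compound 2. Ring nitrogen is therefore not needed at this position to reach the number of compound 3.

Nothing available explains these numbers. On these data alone, whether an amine, a carboxylic acid or a longer alkyl ether at this carbon would keep the number of compound 4 remains open.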